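The compounds below may be only part of what the source reports. "The series", "measured", "known", "first", "only" and "open" are said of these compounds alone.

Measured compounds:
Compound 1, `CC(Oc1ccccc1-c1ccc([N+](=O)[O-])cc1)C1=NCCN1`: 501 nM
Compound 2, `CC(Oc1ccccc1-c1ccncc1)C1=NCCN1`: 2690 nM
Compound 3, `CC(Oc1ccccc1-c1ccccc1)C1=NCCO1`: 10000 nM

All three numbers come from an assay on CHO cells for displacement of a labelled ligand from Alpha-2B adrenergic receptor (Homo sapiens); a higher number here means a weaker inhibitor, a lower number a stronger inhibitor. Among them compound 2 stands second highest: compound 1 gives a lower number, and the gap between the two lies beyond the usual scatter, while compound 3 gives a higher number, again by a gap beyond the scatter. Compound 2 thus sits between its two neighbours rather than at either end.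

Compound 4, `CC(Oc1ccccc1-c1cccs1)C1=NCCN1`, has not yet been tested. It differs from compound 2 in a single place: thiophen-2-yl in place of pyridin-4-yl on an aromatic carbon. For the measured compounds named here, no pair of measured compounds shares this exchange, so its effect cannot be read from the numbers at hand. The working expectation is a small move toward a lower number, of a size that may not clear the scatter, so that the step of a 2.1-fold lower number from compound 2 to compound 4 (0.32 log units; beyond the scatter) is expected. Compound 4 is accordingly estimated at 1300 nM in this assay, within a range from 400 nM to 4500 nM.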

Compound 4, inhibition constant: 214 nM
Beside the measured number, compound 4's estimate is 6.1-fold (0.78 log units) above it, and the stated range ends above it.
By their numbers in this assay, from the lowest: compound 4; then compound 1; then compound 2; then compound 3.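

In this assay, exchanging pyridin-4-yl for thiophen-2-yl gives a 13-fold lower number from compound 2 to compound 4 (1.10 log units; beyond the scatter) and so shows that the ring on this aromatic carbon, ortho to a group of 8 heavy atoms, can change the number strongly. The two groups have the same counts of hetero atoms, hydrogen-bond donors and hydrogen-bond acceptors and carry no net charge, so those counts do not separate them; they differ in ring size and in having sulfur rather than nitrogen as the hetero atom. Nothing available explains why the number falls.

On these data alone, it remains open whether this step is specific to thiophen-2-yl or would also appear with a furan-2-yl or thiophen-3-yl group, or with a non-ring group such as an amine or a carboxylic acid. As far as these compounds go, it is also open whether the same exchange would have a similar effect on the core of compound 3.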